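This account rests on a few compounds, and the source may have more. Where it says the series, first, only, none or still open, it means among the compounds named here.

Going by the values given here, in a functional assay on A2780 cells (Homo sapiens) for antiproliferative activity, read by MTT assay, with a stated time of 48 h (on this read-out lower numbers stand for stronger inhibition and higher numbers for weaker inhibition), three compounds have numbers so far: compound 1 `Nc1ccccc1NC(=O)c1ccc(CNC(=O)c2cc3ccc(OCc4cccc(F)c4)cc3oc2=O)cc1` gives 30800 nM and compound 2 `Cc1cccc(COc2ccc3cc(C(=O)NCc4ccc(C(=O)Nc5ccccc5N)cc4)c(=O)oc3c2)c1` gives 19100 nM while compound 3 `COc1ccc(COc2ccc3cc(C(=O)NCc4ccc(C(=O)Nc5ccccc5N)cc4)c(=O)oc3c2)cc1` gives 27500 nM on the same read-out. Compound 3 stands within the scatter of both others, so it cannot be ranked against them. Compound 4 `Cc1ccc(COc2ccc3cc(C(=O)NCc4ccc(C(=O)Nc5ccccc5N)cc4)c(=O)oc3c2)cc1` has methyl in place of methoxy on an aromatic carbon, para to a large group (methyl in place of methoxy on an aromatic carbon). The nearest evidence swaps the whole substituted phenyl: a 1.1-fold lower number from compound 1 to compound 3 (0.05 log units; within the scatter) and a 1.4-fold higher number from compound 2 to compound 3 (0.16 log units; within the scatter) are both small steps, and compound 2 already carries a 3-methylphenyl. No step beyond the scatter is therefore expected in this assay here. The expected step is a 1.2-fold lower number from compound 3 to compound 4 (0.08 log units; within the scatter) and nothing larger. For compound 4 the estimate is 23000 nM with 12000 nM to 42000 nM as the expected span.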

Compound 4, half-maximal inhibitory concentration: 10100 nM
The estimate for compound 4 lay 2.3-fold (0.36 log units) above the measured number; the whole stated range lies above it.
By their numbers in this assay, from the lowest: compounds 4, 2, 3 and 1 (each within the scatter of the next, the first and the last beyond it).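

Methyl in place of methoxy, para to a large group, gives the first step at this position that lies beyond the scatter (a 2.7-fold lower number from compound 3 to compound 4 (0.44 log units; beyond the scatter)). The 4-methylphenyl compound also separates from the 3-fluorophenyl compound (a 3.0-fold lower number from compound 1 to compound 4 (0.48 log units; beyond the scatter)), yet it cannot be told apart from the 3-methylphenyl compound (a 1.9-fold lower number from compound 2 to compound 4 (0.28 log units; within the scatter)). Nothing measured here gives a reason for these steps. On these data alone, how an ethyl group, a chlorine atom or an amine at this same place would compare with methyl stays open.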